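The compounds below may be only part of what the source reports. "The series", "measured", "known", "first", "only" and "open" are said of these compounds alone.

Going by the values given here, compound 2 `COc1ccc(C2CC(c3cc(Cl)c(C)cc3O)=NN2c2ccc(S(N)(=O)=O)cc2)cc1OC` gives the lowest of the two numbers so far in a functional assay on DU-145 cells (Homo sapiens) for antiproliferative activity, with a stated time of 48 h (on this read-out lower numbers stand for stronger inhibition of growth and higher numbers for weaker inhibition of growth), namely 21700 nM, while compound 1 `Cc1cc(O)c(C2=NN(c3ccc(S(N)(=O)=O)cc3)C(/C=C/c3ccccc3)C2)cc1Cl` gives 38600 nM; the step of a 1.8-fold lower number from compound 1 to compound 2 (0.25 log units; within the scatter) stays within the scatter. Compound 3 `COc1ccc(C2CC(c3cc(Cl)c(C)cc3O)=NN2c2ccc(S(N)(=O)=O)cc2)c(OC)c1OC` differs from compound 2 by methoxy in place of hydrogen on an aromatic carbon. Among the compounds with values here, no measured step touches an added methoxy on that aromatic ring, so the only guide is that the one change seen so far moved little. Compound 3 is therefore expected to show a 1.1-fold lower number from compound 2 to compound 3 (0.04 log units; within the scatter) in this assay, and its value is estimated at 20000 nM, within 7000 nM to 55000 nM.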

Compound 3, concentration for total growth inhibition: 11200 nM
The estimate for compound 3 lay 1.8-fold (0.25 log units) above the measured number; measured number inside the range.
By their numbers in this assay, from the lowest: compounds 3, 2 and 1 (each within the scatter of the next, the first and the last beyond it).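

In this assay, methoxy in place of hydrogen on this aromatic carbon, ortho to a large group, gives a step that stays within the scatter (a 1.9-fold lower number from compound 2 to compound 3 (0.29 log units; within the scatter)), so this change alone does not separate the two compounds. Going by these compounds alone, replacing 2-phenylethenyl with 2,3,4-trimethoxyphenyl, however, gives the only step so far beyond the scatter, though a modest one (a 3.4-fold lower number from compound 1 to compound 3 (0.54 log units; beyond the scatter)). Nothing at hand accounts for either step. On these data alone, whether an amine, a carboxylic acid or a longer chain such as ethoxy on that same carbon would shift the number remains open.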